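Replacing the (4-fluorobenzyl)oxy Group with 1H-imidazol-1-yl

The compounds below may be only part of what the source reports. "The series", "measured", "known", "first", "only" and "open" are said of these compounds alone.

Compound 1, `Nc1nc(N/N=C/c2ccc(OCc3ccc(F)cc3)cc2)nc2c1ncn2[C@@H]1O[C@H](CO)[C@@H](O)[C@H]1O`: 70 nM.
Compound 2, `CC(=O)Nc1ccc(/C=N/Nc2nc(N)c3ncn([C@@H]4O[C@H](CO)[C@@H](O)[C@H]4O)c3n2)cc1`: > 10000 nM, which is a limit of the assay and not a number.
Compound 3, `Nc1nc(N/N=C/c2ccc(-c3ccccc3)cc2)nc2c1ncn2[C@@H]1O[C@H](CO)[C@@H](O)[C@H]1O`: 7860 nM.

All three were tested in an assay on CHO-K1 cells for displacement of a labelled ligand from adenosine receptor A1 (Homo sapiens), read by scintillation counting, with a stated time of 60 min; a higher number here means a weaker inhibitor, a lower number a stronger inhibitor. Compound 1 gives the lowest of the two actual numbers; compound 3 is a 110-fold higher number from compound 1 to compound 3 (2.05 log units; beyond the scatter) away. Compound 2 reaches only (the limit of > 10000 nM in this assay, at which 1 of the 3 values shown sits).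

Compound 4, `Nc1nc(N/N=C/c2ccc(-n3ccnc3)cc2)nc2c1ncn2[C@@H]1O[C@H](CO)[C@@H](O)[C@H]1O`, has not yet been measured. It differs from compound 1 in one place: 1H-imidazol-1-yl in place of (4-fluorobenzyl)oxy on an aromatic carbon. Two measured steps start from compound 1 and bear on this change: an at least 140-fold higher number from compound 1 to compound 2 (2.15 log units; beyond the scatter) and a 110-fold higher number from compound 1 to compound 3 (2.05 log units; beyond the scatter). Of these, compound 3 is the closer comparison, since its phenyl is also a small aromatic ring standing where the (4-fluorobenzyl)oxy group stood in compound 1, and it lost heavily. Compound 2 and compound 3 differ little from each other: an at least 1.2-fold lower number from compound 2 to compound 3 (0.10 log units; that floor lies within the scatter). Both replacements of the (4-fluorobenzyl)oxy group, therefore, led to a much higher number.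

A large step toward a higher number, meaning weaker inhibition in this assay, is therefore expected for compound 4, namely a 71-fold higher number from compound 1 to compound 4 (1.85 log units; beyond the scatter). Compound 4 is estimated at 5000 nM, with a range from 1000 nM to 20000 nM.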

Compound 4, inhibition constant: > 10000 nM
Compound 4 gave a limit, no number (the forecaster's own chance of this, stated with the estimate: 25%); at least 2.0-fold (0.30 log units) between middle value and limit.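

Imidazole now joins phenyl and acetamido as a third, quite different replacement for the (4-fluorobenzyl)oxy group on this aromatic carbon, and the outcome is the same: in this assay, the change gives an at least 140-fold higher number from compound 1 to compound 4 (2.15 log units; beyond the scatter), so the heavy loss is not tied to one kind of incoming group. Swapping the six-membered all-carbon ring of compound 3 for the five-membered ring with two hetero atoms gives an at least 1.2-fold higher number from compound 3 to compound 4 (0.10 log units; that floor lies within the scatter), so the added ring nitrogens bring no recovery and the two groups cannot be told apart, while the step between compound 2 and compound 4 cannot be read at all. Compound 4 stands at a limit of the assay and not at a number, which makes it the second such compound in this set: the limit of > 10000 nM in this assay, at which 2 of the 4 values shown sit.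

The compounds shown leave open which part of the (4-fluorobenzyl)oxy group matters, for instance whether a plain benzyloxy group without the fluorine, or a benzylamino group with nitrogen as the link, would hold the value of compound 1. They also leave open how a small methoxy group or a longer chain such as butoxy would behave at this position.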